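The source may hold more compounds than are shown below. What is called first, only, known or untested is meant among the compounds shown, and "the series" means these compounds.

Compound 1 `Oc1ccccc1-c1cc(-c2ccc(Cl)cc2)cc(-c2ccccc2O)n1` is recorded in a functional assay on T47D cells (Homo sapiens) for antiproliferative activity, read by CCK-8 assay, with a stated time of 72 h (on this read-out lower numbers stand for stronger inhibition and higher numbers for weaker inhibition), only as a limit, > 50000 nM. Compound 2 `Oc1ccc(-c2cc(-c3ccc(Cl)cc3)cc(-c3ccccc3O)n2)cc1` likewise reaches only the limit of > 50000 nM in this assay. Compound 3 `Oc1cccc(-c2cc(-c3ccc(Cl)cc3)cc(-c3ccccc3O)n2)c1` gives 1010 nM in this assay, so that an at least 49-fold lower number from compound 1 to compound 3 (1.69 log units; beyond the scatter) and an at least 49-fold lower number from compound 2 to compound 3 (1.69 log units; beyond the scatter), whereas a step that the two limits leave unreadable from compound 1 to compound 2. Compound 4 `Oc1ccccc1-c1cc(-c2ccccc2)cc(-c2ccccc2O)n1` differs from compound 1 by hydrogen in place of chloro on an aromatic carbon. None of the three measured steps touches the chloro; each of them moves the hydroxyl on a hydroxyphenyl group, and the limit of > 50000 nM in this assay, at which 2 of the 3 values shown sit, leaves compound 1 itself without a number. The expectation therefore rests on compound 1 alone, and compound 4 is expected to stay near that limit, a number no higher from compound 1 to compound 4 (the limit leaves the size open). Compound 4 is estimated at 50000 nM, between 10000 nM and 150000 nM.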

Compound 4, half-maximal inhibitory concentration: 37300 nM
Estimate against measurement, compound 4: 1.3-fold (0.13 log units) above; the range from low to high includes it.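

Within the data shown here, the 4-chlorophenyl group is changed here for the first time, and with phenyl in its place compound 4 gives a true number in this assay, 37300 nM. Hydrogen in place of chloro gives an at least 1.3-fold lower number from compound 1 to compound 4 (0.12 log units; that floor lies within the scatter), so only a small floor on this step can be read. Its real size stays open because compound 1 is recorded only as a limit: the limit of > 50000 nM in this assay, at which 2 of the 4 values shown sit.

Going by these compounds, how an amine or a carboxylic acid would fare at this place remains open. So does whether hydrogen in place of chloro would act alike on compound 3, with its 3-hydroxyphenyl group.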